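Swapping fluoro for hydroxy on an acetylated compound

A few compounds are considered here, and "the series" means these few. Any claim that something is new, unique, unknown or untested is made for them only; others in the source may bear on it.

Compound 1 `COc1ccc(C2=C(c3cc(OC)c(OC)c(OC)c3)C(=O)C(OC(C)=O)C2)cc1F` gives 33 ug/mL
Compound 2 `COc1ccc(C2=C(c3cc(OC)c(OC)c(OC)c3)C(=O)C(O)C2)cc1F` gives 4.5 ug/mL
Compound 3 `COc1ccc(C2=C(c3cc(OC)c(OC)c(OC)c3)C(=O)C(OC(C)=O)C2)cc1O` has not yet been measured

Both values come from an ADME assay on KB cells (Homo sapiens) for cytotoxicity, read by MTT assay, with a stated time of 72 h; on this read-out lower numbers stand for stronger inhibition and higher numbers for weaker inhibition. Compound 1 holds the higher of the two numbers, which makes it the weaker inhibitor of this pair.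

Compound 3 keeps the acetyl group of compound 1 and changes the aromatic ring instead: hydroxy in place of fluoro on an aromatic carbon. In words, the 3-fluoro-4-methoxyphenyl group becomes a 3-hydroxy-4-methoxyphenyl group.

Among the compounds with values here, no measured pair tests this exchange directly. Within the data shown here, the only measured step, a 7.3-fold lower number from compound 1 to compound 2 (0.87 log units; beyond the scatter), replaces acetyl with hydrogen on an oxygen on a saturated carbon, so it concerns a different part of the molecule. Its bearing is therefore indirect: it shows that one small change can move a number in this assay by a modest amount, beyond the scatter. Among the measured compounds shown here, since compound 1 sits at the high end of the numbers so far, a modest move downward in this assay is the likelier outcome, though a step within the scatter remains possible. The expected change is a 3.3-fold lower number from compound 1 to compound 3 (0.52 log units; beyond the scatter). Compound 3 is estimated at 10 ug/mL, with an expected range from 2 ug/mL to 45 ug/mL.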

Compound 3, half-maximal inhibitory concentration: 35 ug/mL
Estimate against measurement, compound 3: 3.5-fold (0.54 log units) below; the measured number falls inside the stated range.
By their numbers in this assay, from the lowest: compound 2; then compounds 1 and 3 (each within the scatter of the next).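

In this assay, hydroxy in place of fluoro gives a 1.1-fold higher number from compound 1 to compound 3 (0.03 log units; within the scatter), so with the acetyl group present, this exchange on the aromatic ring produces no change that can be told apart from ordinary repeat variation, even though a hydrogen-bond donor and a hydrogen-bond acceptor enter with the hydroxy. Within the data shown here, the contrast with the other change made to compound 1 is clear: replacing acetyl with hydrogen on the oxygen on a saturated carbon gives a 7.3-fold lower number from compound 1 to compound 2 (0.87 log units; beyond the scatter), so of these two single changes, only that one moves the number beyond the scatter. No supporting evidence is available to explain why the aromatic exchange leaves the number within the scatter.

Going by these compounds, whether the same exchange would behave alike in compound 2, which has hydrogen instead of acetyl on that oxygen, remains open. Also open, on these data alone, is how this aromatic position would respond to a larger change, such as an amine, a chlorine atom or a longer chain like ethoxy in place of the fluoro of compound 1.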